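Swapping Chloro for Bromo on a Shared Core

The source may report more compounds than this note shows. Statements on the series, on what has been measured and on what is new or still open speak of the compounds shown alone.

Measured compounds:
compound 1 `c1ccc2c(-c3cn4ccnc4c(-c4ccc5ncn(C6CCCCC6)c5c4)n3)cccc2c1` — 20.8%
compound 2 `c1cn2cc(-c3ccsc3)nc(-c3ccc4ncn(C5CCCCC5)c4c3)c2n1` — 1.35%
compound 3 `Clc1ccc(-c2cn3ccnc3c(-c3ccc4ncn(C5CCCCC5)c4c3)n2)cc1` — 15.3%

Three compounds share one core and differ only in the group attached to an aromatic carbon of that core. In a functional assay on MDA-MB-231 cells (Homo sapiens) for inhibition, read by sulforhodamine B assay, with a stated time of 48 h, tested at 10 uM (on this read-out lower numbers stand for less inhibition and higher numbers for more inhibition at the one concentration tested (going by the name of the read-out)), compound 3 holds the second highest of the three numbers. Its nearest neighbour is compound 1, and the step of a number 5.5 percentage points lower from compound 1 to compound 3 (within the scatter) lies within the scatter, so the two cannot be told apart. Its furthest neighbour is compound 2, and the step of a number 14 percentage points higher from compound 2 to compound 3 (beyond the scatter) lies beyond the scatter, as does the step of a number 19.5 percentage points lower from compound 1 to compound 2 (beyond the scatter).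

Compound 4 `Brc1ccc(-c2cn3ccnc3c(-c3ccc4ncn(C5CCCCC5)c4c3)n2)cc1` is the next compound. Compared with compound 3, the change is bromo in place of chloro on an aromatic carbon. For the measured compounds named here, none of the measured steps swaps one halogen for another; they all exchange whole ring groups, and the smallest of them, from compound 1 to compound 3, stayed within the scatter. A single halogen swap on the same ring is a smaller change than any of those, so no step beyond the scatter is expected in this assay, which the estimated step of a number 1.7 percentage points higher from compound 3 to compound 4 (within the scatter) expresses.

For compound 4 the estimated value is 17%, expected to fall between 5% and 30%.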

Compound 4, a percentage reported as inhibition, at one concentration (the size of the read-out at that concentration, not a potency): 22.8%
Estimate against measurement, compound 4: 5.8 percentage points below, within the range that was stated.
By their numbers in this assay, from the lowest: compound 2; then compounds 3, 1 and 4 (each within the scatter of the next).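

In this assay, for the compounds shown here, the first direct halogen exchange at this place gives a number 7.5 percentage points higher from compound 3 to compound 4 (within the scatter) and so chloro and bromo on the phenyl ring cannot be told apart here. The comparison between whole ring groups reads the same way: a number 2 percentage points higher from compound 1 to compound 4 (within the scatter) means 4-bromophenyl and naphthalen-1-yl cannot be separated either, while a number 21.5 percentage points higher from compound 2 to compound 4 (beyond the scatter) sets 4-bromophenyl clearly apart from thiophen-3-yl. Taken with the earlier steps, this leaves compound 2, which carries the thiophen-3-yl group, as the lowest of the four and the only one that stands apart, whereas compounds 1, 3 and 4 form a single group that cannot be ranked.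

The compounds shown leave open whether an amine, a carboxylic acid or a longer chain on the phenyl ring, in place of the halogen, would keep the number at this level or move it beyond the scatter. Nothing shown here gives a measured property of these groups that bears on the result.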